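This account rests on a few compounds, and the source may have more. Where it says the series, first, only, none or still open, it means among the compounds named here.

Measured compounds in an assay on liver for inhibition of sterol O-acyltransferase 1 (Rattus norvegicus), using microsomes; on this read-out higher numbers stand for weaker inhibition and lower numbers for stronger inhibition:

compound 1 `CCCCCCNS(=O)(=O)NC(=O)Nc1c(C(C)C)cccc1C(C)C` — 8100 nM
compound 2 `CC(C)c1cccc(C(C)C)c1NC(=O)NS(=O)(=O)N1CCCCC1` — 17000 nM

For the measured compounds named here, compound 2 gives the higher of the two numbers; its nearest neighbour is compound 1, and the single measured step, a 2.1-fold higher number from compound 1 to compound 2 (0.32 log units; beyond the scatter), is a modest one beyond the scatter. So of the two compounds in hand, compound 2 is the weaker inhibitor on this assay.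

Compound 3 `CC(C)c1cccc(C(C)C)c1NC(=O)NS(=O)(=O)N1CCC(c2ccccc2)CC1` is not yet measured. It differs from compound 2 by phenyl in place of hydrogen on a saturated ring carbon; the shared core of compounds 2 and 3 is otherwise unchanged.

Going by the values given here, no measured step bears on this change. Among the compounds with values here, the only step in hand, a 2.1-fold higher number from compound 1 to compound 2 (0.32 log units; beyond the scatter), swaps the whole group on the sulfonyl sulfur and says nothing about adding a group to a ring carbon of the piperidin-1-yl. Within the data shown here, the only hint is that compound 1, with the longer hexylamino group, gives a lower number than compound 2, which carries the bare ring. On that slim basis, the expected step from compound 2 to compound 3 is a 1.7-fold lower number from compound 2 to compound 3 (0.23 log units; within the scatter), with wide uncertainty in both directions.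

Compound 3 is therefore estimated at 10000 nM, expected to fall between 3000 nM and 35000 nM.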

Compound 3, half-maximal inhibitory concentration: 10400 nM
Compound 3: the middle estimate sits 1.0-fold (0.02 log units) below what was measured; measured number inside the range.
By their numbers in this assay, from the lowest: compounds 1, 3 and 2 (each within the scatter of the next, the first and the last beyond it).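

In this assay, phenyl in place of hydrogen on a saturated ring carbon, three ring bonds from the ring nitrogen, gives a 1.6-fold lower number from compound 2 to compound 3 (0.21 log units; within the scatter), so the two compounds cannot be told apart on this read-out. For the compounds shown here, this is the first reading at this ring carbon: the earlier step swapped the whole group on the sulfonyl sulfur, whereas this one shows that the piperidin-1-yl can carry an added aromatic ring of six heavy atoms with the number staying within the scatter of the unsubstituted ring. No measurement available here explains this outcome, and nothing given on compound 3 goes beyond its number in this one assay.

From the compounds shown here alone, a single substituent cannot define a trend at this ring carbon, so it remains open whether a methyl, a hydroxyl, a carboxylic acid or a primary amine there would also stay within the scatter of compound 2 or would move the number beyond it. Also open, going by these compounds, is whether a benzyl group or a longer alkyl chain on the same carbon, or a substituted phenyl in place of the plain one, would bring a step beyond the scatter in either direction.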